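The source may report more compounds than this note shows. Statements on the series, on what has been measured and on what is new or still open speak of the compounds shown alone.

Measured in a physicochemical assay for pharmacokinetics, at pH 6; a lower number here means that the compound disappears faster, a higher number that the compound lasts longer:
- compound 1 `O=C(Sc1cccnc1C(=O)O)c1ccc(C(F)(F)F)cc1`: 3 h
- compound 2 `Cc1ccc(C(=O)Sc2cccnc2C(=O)O)cc1`: 25.6 h

Of these two compounds, compound 2 has the higher number, at 25.6 h, and its gap to compound 1 lies beyond the scatter. Next comes compound 3 `O=C(Sc1cccnc1C(=O)O)c1ccc(F)cc1`, which differs from compound 2 as follows: fluoro in place of methyl on an aromatic carbon. This is fluoro in place of methyl on an aromatic carbon, para to a large group.

Within the data shown here, one measured step bears on this change: an 8.5-fold higher number from compound 1 to compound 2 (0.93 log units; beyond the scatter), a modest step with methyl in place of trifluoromethyl at the same place. Among the measured compounds shown here, with only that step to go on, a lower number than compound 2 is expected, and a smaller change than that step. The estimated step is a 2.1-fold lower number from compound 2 to compound 3 (0.33 log units; beyond the scatter), close to the edge of the scatter. For compound 3 the expected half-life in this assay is 12 h, with an estimated range of 6 h to 22 h.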

Compound 3, half-life: 12.1 h
Beside the measured number, compound 3's estimate is 1.0-fold (0.00 log units) below it, and the stated range covers the measured number.
By their numbers in this assay, from the lowest: compound 1; then compound 3; then compound 2.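

In this assay, the aromatic carbon para to a large group now has three groups compared, with fluoro falling between trifluoromethyl and methyl: the series shows a 2.1-fold lower number from compound 2 to compound 3 (0.33 log units; beyond the scatter) and a 4.0-fold higher number from compound 1 to compound 3 (0.61 log units; beyond the scatter), both read here as real differences. A single fluoro therefore does not match trifluoromethyl at this place, so the presence of fluorine alone does not set the number across compound 1 and compound 3. No available measurement accounts for this order.

Still open, as far as these compounds go, is whether chloro, methoxy or an amine at this place would fall within the span set by these three groups, or whether a longer chain would extend it. From the compounds shown here alone, the order is also tied to this one place on the shared core, and how the same groups rank elsewhere on it remains open.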